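From methanesulfonamido to methoxy: notes on compound 4

A few compounds are considered here, and "the series" means these few. Any claim that something is new, unique, unknown or untested is made for them only; others in the source may bear on it.

Of the compounds shown here, three sharing a core have been read in a functional assay on HeLa cells (Homo sapiens) for cytotoxicity, read by resazurin assay, with a stated time of 72 h (a lower number here means a stronger inhibitor, a higher number a weaker inhibitor), so far. Compound 2 (`CCSC(=S)SCC(=O)c1ccc(NS(C)(=O)=O)cc1`) gives 45800 nM and compound 3 (`CCSC(=S)SCC(=O)c1ccc(C(=O)Nc2ccccc2)cc1`) gives 25800 nM, two values within the scatter of each other. Compound 1 (`CCSC(=S)SCC(=O)c1cccc(C(=O)Nc2ccccc2)c1`) gives 2400 nM, which lies lower than the number for compound 2 by more than the scatter. Compound 2 therefore stands level with compound 3 and clearly apart from compound 1.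

Compound 4 (`CCSC(=S)SCC(=O)c1ccc(OC)cc1`) has not been measured. Its structural change from compound 2 is as follows: methoxy in place of methanesulfonamido on an aromatic carbon. Going by the values given here, no measured pair shows this exchange directly, so the expectation rests on thin ground. With a different group at that place, compound 3 reads 25800 nM, close to compound 2, and this suggests that compound 4 will stay in the same region. No step beyond the scatter is expected in this assay, although a modest fall in the number remains possible. The expected change is a 1.5-fold lower number from compound 2 to compound 4 (0.18 log units; within the scatter), within the scatter. The estimate for compound 4 is 30000 nM, with an expected range from 10000 nM to 80000 nM.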

Compound 4, half-maximal inhibitory concentration: 1960 nM
Estimate against measurement, compound 4: 15-fold (1.18 log units) above; measured number below the stated range.
By their numbers in this assay, from the lowest: compounds 4 and 1 (each within the scatter of the next); then compounds 3 and 2 (each within the scatter of the next).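

In this assay, methoxy in place of methanesulfonamido on the aromatic carbon gives a 23-fold lower number from compound 2 to compound 4 (1.37 log units; beyond the scatter), so the group at this place can shift the number well beyond the scatter. Compounds 2 and 3 had read close together and gave no sign of this; now compound 3 at 25800 nM and compound 4 at 1960 nM show that the position does not respond alike to every group placed there. The exchange removes a group of 5 heavy atoms with 1 hydrogen-bond donor and brings in one of 2 heavy atoms with no donor, but nothing available accounts for the step, and this single pair cannot separate those differences.

As far as these compounds go, how a hydroxyl group, an amine or a longer ether such as ethoxy would read at this place remains open, so it cannot yet be said whether the low number is particular to methoxy. Also open, from the compounds shown here alone, is how methoxy would read at the other ring carbon, where compound 1 carries its substituent.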